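The source may report more compounds than this note shows. Statements on the series, on what has been measured and on what is new or still open speak of the compounds shown alone.

Compound 3 `C/C(=N\OC(CC(C)(C)c1ccccc1)c1ccc(OCc2ccc3ccccc3n2)cc1)C(=O)O` gives 22 nM in a functional assay for inhibition of Polyunsaturated fatty acid 5-lipoxygenase (Homo sapiens) (on this read-out lower numbers stand for stronger inhibition and higher numbers for weaker inhibition), the lowest of the three numbers shown. Compound 2 `C/C(=N\OC(CC1CCCCC1)c1ccc(OCc2ccc3ccccc3n2)cc1)C(=O)O` gives 29 nM, and the gap is a 1.3-fold lower number from compound 2 to compound 3 (0.12 log units; within the scatter), within the scatter. Compound 1 `C=CCC(O/N=C(\C)C(=O)O)c1ccc(OCc2ccc3ccccc3n2)cc1` gives 142 nM. Compound 4 `C/C(=N\OCc1ccc(OCc2ccc3ccccc3n2)cc1)C(=O)O` differs from compound 3 by hydrogen in place of 2-methyl-2-phenylpropyl on a saturated chain carbon bound to an aromatic carbon and an oxygen. Both measured steps that bear on this change enlarge the group at that carbon: a 4.9-fold lower number from compound 1 to compound 2 (0.69 log units; beyond the scatter) and a 6.5-fold lower number from compound 1 to compound 3 (0.81 log units; beyond the scatter). Removing the group entirely moves further in the opposite direction than any measured step, so compound 4 is expected to show a rise beyond the scatter, likely at least as large as a 6.5-fold lower number from compound 1 to compound 3 (0.81 log units; beyond the scatter). Compound 4 is therefore estimated at 400 nM, between 130 nM and 1300 nM. This expectation amounts to an 18-fold higher number from compound 3 to compound 4 (1.26 log units; beyond the scatter).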

Compound 4, half-maximal inhibitory concentration: 1400 nM
For compound 4 the middle estimate is 3.5-fold (0.54 log units) below the measured one; measured number above the stated range.
By their numbers in this assay, from the lowest: compounds 3 and 2 (each within the scatter of the next); then compound 1; then compound 4.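

Taking the group away altogether costs far more than any earlier step suggested, with a 64-fold higher number from compound 3 to compound 4 (1.80 log units; beyond the scatter) and a 48-fold higher number from compound 2 to compound 4 (1.68 log units; beyond the scatter) both large. Even the allyl of compound 1 counts, since hydrogen in its place still gives a 9.9-fold higher number from compound 1 to compound 4 (0.99 log units; beyond the scatter), so all three groups at this saturated chain carbon give lower numbers in this assay than hydrogen does. Nothing measured here explains why a group at this carbon matters so much. From the compounds shown here alone, what a single methyl or a hydroxymethyl at this carbon would give remains open, and so does how short a chain could keep the lower numbers.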